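A few compounds are considered here, and "the series" means these few. Any claim that something is new, unique, unknown or untested is made for them only; others in the source may bear on it.

The measured compounds, in an ADME assay on microsomes from liver (Rattus norvegicus) for metabolic stability, read by LC-MS, using NADPH; a higher number here means that the compound lasts longer, a lower number that the compound disappears faster:
compound 1 `O=C(NCCCCN1CCN(c2cccc(O)c2)CC1)c1ccc(-c2ccsc2)cc1` gives 0.085 h;
compound 2 `O=C(NCCCCN1CCN(c2ccc(O)cc2)CC1)c1ccc(-c2ccsc2)cc1` gives 0.19 h;
compound 3 `N#Cc1cccc(N2CCN(CCCCNC(=O)c3ccc(-c4ccsc4)cc3)CC2)c1` gives a limit only, > 1 h.

Compound 3 stands at the top of what this set shows: the limit of > 1 h in this assay, at which 1 of the 3 values shown sits, so its true half-life is not pinned down. The two steps that reach compound 3 are both beyond the scatter, an at least 11-fold higher number from compound 1 to compound 3 (1.07 log units; beyond the scatter) and an at least 5.2-fold higher number from compound 2 to compound 3 (0.72 log units; beyond the scatter), while the step between the two hydroxy compounds is smaller, a 2.2-fold higher number from compound 1 to compound 2 (0.35 log units; beyond the scatter). Compound 4 `O=C(NCCCCN1CCN(c2ccc(C(F)(F)F)cc2)CC1)c1ccc(-c2ccsc2)cc1` differs from compound 3 by 4-(trifluoromethyl)phenyl in place of 3-cyanophenyl on an amine nitrogen in a ring. Among the compounds with values here, no measured step carries this exact change. Within the data shown here, the steps that bear on it, an at least 11-fold higher number from compound 1 to compound 3 (1.07 log units; beyond the scatter) and an at least 5.2-fold higher number from compound 2 to compound 3 (0.72 log units; beyond the scatter), show only that replacing a hydroxy-bearing ring on that ring nitrogen by the 3-cyanophenyl ring took compound 3 to the limit; the 4-(trifluoromethyl)phenyl ring of compound 4 likewise carries no hydroxy, so compound 4 is expected to stay at or near that limit. The step of a number no higher from compound 3 to compound 4 (the limit leaves the size open) is expected to be small. Compound 4 is estimated at 1 h, within 0.4 h to 2.5 h.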

Compound 4, half-life: > 1 h
Compound 4 gave a limit, no number (the forecaster's own chance of this, stated with the estimate: 55%); the middle value lies on the limit itself.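

In this assay a second ring without hydroxy on the amine nitrogen in a ring, 4-(trifluoromethyl)phenyl, reaches the top of the set alongside 3-cyanophenyl: the limit of > 1 h in this assay, at which 2 of the 4 values shown sit. Against the hydroxy compounds the change gives an at least 5.2-fold higher number from compound 2 to compound 4 (0.72 log units; beyond the scatter) and an at least 11-fold higher number from compound 1 to compound 4 (1.07 log units; beyond the scatter), so among the compounds shown, the two rings carrying hydroxy have the lower numbers and the two rings without it do not, with no compound going against this. The step between the two limit values cannot be read, so neither ring can be placed ahead of the other.

From the compounds shown here alone, how far the true half-lives of compound 3 and compound 4 lie past the limit stays open. Also open, going by these compounds, is whether a methoxy group or a chlorine atom on this ring, or a longer chain in the linker, would hold the same result.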